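The source may report more compounds than this note shows. Statements on the series, on what has been measured and on what is new or still open speak of the compounds shown alone.

Measured so far in a physicochemical assay for lipophilicity, in phosphate buffer, measured as octanol-water partition, at pH 11.5; a higher number here means a more lipophilic compound, a lower number a more polar compound:

compound 1 `CCCCCCCCNC(=N)NC(=N)Nc1ccccc1`: 4.43
compound 2 `CCCCC(CC)CNC(=N)NC(=N)Nc1ccc(Cl)cc1`: 4.93
compound 3 `CCSc1ccc(NC(=N)NC(=N)NCCCCCCNC(=N)NC(=N)Nc2ccc(SCC)cc2)cc1`: 5.58

Compound 1 stands lowest of the three, and the gaps up to compound 2 and compound 3 both lie beyond the usual scatter of repeated measurements. The next compound to be measured, compound 4 `CCCCCCCCNC(=N)NC(=N)Nc1ccc(OC)cc1`, keeps the core of compound 1 and changes it in one place: methoxy in place of hydrogen on an aromatic carbon.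

For the measured compounds named here, no two measured compounds differ in just one place, so the data give no direct measure of what this change does. Compound 2 and compound 3 each differ from compound 1 in more than one place and cannot size it. The expectation therefore starts from compound 1 at 4.43, with no step beyond the scatter expected in this assay. Going by these compounds, the expected change is a number 0.03 log units lower from compound 1 to compound 4 (within the scatter), and its direction remains open. For compound 4 the estimated value is 4.4, with an expected range from 4 to 4.8.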

Compound 4, partition coefficient: 4.41
Compound 4: the middle estimate sits 0.01 log units below what was measured; the measured number falls inside the stated range.
By their numbers in this assay, from the lowest: compounds 4 and 1 (each within the scatter of the next); then compound 2; then compound 3.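

In this assay, putting methoxy in place of hydrogen on an aromatic carbon, para to a large group, gives a number 0.02 log units lower from compound 1 to compound 4 (within the scatter). For the compounds shown here, this is the first pair of measured compounds that differ in just one place, so the change now has a directly measured size: at this position on the core of compound 1, adding methoxy's 2 heavy atoms leaves the two numbers indistinguishable. Nothing available bears on why the step has this size.

This single pair cannot show whether an amine or a carboxylic acid at the same position would also leave the number within the scatter. It also leaves open whether methoxy would behave the same way on a core with a shorter or branched chain in place of the octyl chain.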